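Fluoro to chloro on the ethyl side chain

A few compounds are considered here, and "the series" means these few. Any claim that something is new, unique, unknown or untested is made for them only; others in the source may bear on it.

Measured in a functional assay on MCF7 cells (Homo sapiens) for cytotoxicity, read by CellTiter-Glo, with a stated time of 5 days; on this read-out lower numbers stand for stronger inhibition and higher numbers for weaker inhibition:
compound 1 `C/C(=C(/c1ccc(/C=C/C(=O)O)cc1)c1ccc2[nH]ncc2c1)c1ccccc1`: 40 nM
compound 2 `CCC/C(=C(/c1ccc(/C=C/C(=O)O)cc1)c1ccc2[nH]ncc2c1)c1ccccc1`: 11 nM
compound 3 `O=C(O)/C=C/c1ccc(/C(=C(/CCF)c2ccccc2)c2ccc3[nH]ncc3c2)cc1`: 2.1 nM

Compound 3 gives the lowest number of the three; the nearest is compound 2, with a 5.2-fold lower number from compound 2 to compound 3 (0.72 log units; beyond the scatter), and the furthest is compound 1, with a 19-fold lower number from compound 1 to compound 3 (1.28 log units; beyond the scatter).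

Compound 4 `O=C(O)/C=C/c1ccc(/C(=C(/CCCl)c2ccccc2)c2ccc3[nH]ncc3c2)cc1` differs from compound 3 by chloro in place of fluoro on a saturated chain carbon, two bonds along the chain from a double-bonded chain carbon. Going by the values given here, no measured step swaps one halogen for another at this place. The step of a 5.2-fold lower number from compound 2 to compound 3 (0.72 log units; beyond the scatter) shows that what sits on this chain carbon matters, and a 3.6-fold lower number from compound 1 to compound 2 (0.56 log units; beyond the scatter) shows the chain itself matters. Among the compounds with values here, with no halogen-to-halogen precedent, a small step in this assay is expected, direction uncertain, leaning slightly weaker.

Compound 4 is estimated at 3 nM, within 1 nM to 10 nM, meaning a 1.4-fold higher number from compound 3 to compound 4 (0.15 log units; within the scatter).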

Compound 4, half-maximal inhibitory concentration: 9 nM
For compound 4 the middle estimate is 3.0-fold (0.48 log units) below the measured one, within the range that was stated.
By their numbers in this assay, from the lowest: compound 3; then compounds 4 and 2 (each within the scatter of the next); then compound 1.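

In this assay the identity of the halogen on this saturated chain carbon matters: going from 2-fluoroethyl to 2-chloroethyl gives up much of the low number of the fluoro compound (a 4.3-fold higher number from compound 3 to compound 4 (0.63 log units; beyond the scatter)). Chloro in place of methyl at this place makes no change that can be separated from the scatter (a 1.2-fold lower number from compound 2 to compound 4 (0.09 log units; within the scatter)), while chloromethyl in place of hydrogen still lowers the number (a 4.4-fold lower number from compound 1 to compound 4 (0.65 log units; beyond the scatter)). Nothing available here accounts for the gap between the two halogens. Open, on these data alone, is whether fluoro stands alone at this place: bromo, hydroxyl or an amine on this chain carbon would test that, and a longer chain ending in fluoro would show how far the halogen can sit along the chain.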